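Ethoxycarbonyl anilide in a fatty acid transport series

A few compounds are considered here, and "the series" means these few. Any claim that something is new, unique, unknown or untested is made for them only; others in the source may bear on it.

Compound 1 `CCn1c(CNc2ccccc2)nnc1SCC(=O)Nc1ccc(C(C)=O)cc1` stands as "not determined" (no result reported) in an assay on isolated protein for inhibition of long-chain fatty acid transport protein 1 (Mus musculus); on this read-out higher numbers stand for weaker inhibition and lower numbers for stronger inhibition; no result was reported for it. Going by the values given here, the one measured member, compound 2 `CCn1c(CNc2ccccc2)nnc1SCc1nc2cc(OC(F)(F)F)ccc2o1`, gives 91 nM in this assay, but carries a different group beyond the shared core, so it does not fix where compound 1 stands. Compound 3 `CCOC(=O)c1ccc(NC(=O)CSc2nnc(CNc3ccccc3)n2CC)cc1` is the next member to be measured. It differs from compound 1 by ethoxy in place of methyl on a carbonyl carbon. Among the compounds with values here, no step between measured compounds is available to calibrate this change. The shared core and the anilide are retained; the expectation is a step of modest size in this assay, in either direction or none beyond the scatter. For compound 3 the value in this assay is estimated at 600 nM, within a range from 100 nM to 4000 nM. This estimate is wide, as compound 2 at 91 nM is the only anchor.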

Compound 3, half-maximal inhibitory concentration: 1100 nM
Estimate against measurement, compound 3: 1.8-fold (0.26 log units) below, within the range that was stated.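

No step can be read between compound 1 and compound 3: in this assay compound 1 stands as "not determined" (no result reported) and only compound 3 gives 1100 nM as a number. The compounds shown leave open what acetyl to ethoxycarbonyl changes in inhibition, and no evidence bearing on this result is at hand.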